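Nitrooxy on the methyl of compound 1: stability outlook

The source may report more compounds than this note shows. Statements on the series, on what has been measured and on what is new or still open speak of the compounds shown alone.

Compound 1 `CC(=O)Oc1ccccc1C(=O)O[C@H]1CO[C@H]2[C@@H]1OC[C@H]2OC(=O)c1ccccc1C` is the reference of this set. In an ADME assay on a cell-free system (plasma, Homo sapiens) for metabolic stability, with Plasma (Rattus norvegicus) as the target, read by HPLC, at pH 7.4 (a higher number here means that the compound lasts longer, a lower number that the compound disappears faster), compound 1 gives 0.0138 h, the lowest of the three numbers measured. Compound 2 `COc1ccc(C(=O)O[C@@H]2CO[C@H]3[C@@H]2OC[C@@H]3OC(=O)c2ccccc2OC(C)=O)cc1` gives 0.0183 h in this assay, and compound 3 `CC(=O)Oc1ccccc1C(=O)O[C@H]1CO[C@H]2[C@@H]1OC[C@H]2OC(=O)c1cnccc1Cl` gives 0.0322 h. Among the compounds with values here, the measured steps are a 1.3-fold higher number from compound 1 to compound 2 (0.12 log units; within the scatter), a 2.3-fold higher number from compound 1 to compound 3 (0.37 log units; beyond the scatter) and a 1.8-fold higher number from compound 2 to compound 3 (0.25 log units; within the scatter); only the step to compound 3 exceeds the scatter, and then modestly.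

Compound 4 `CC(=O)Oc1ccccc1C(=O)O[C@H]1CO[C@H]2[C@@H]1OC[C@H]2OC(=O)c1ccccc1CO[N+](=O)[O-]` keeps the core and the 2-methylphenyl ester of compound 1 and differs from it by nitrooxy in place of hydrogen on a saturated chain carbon bound to an aromatic carbon. Within the data shown here, both measured steps from compound 1 swap the whole 2-methylphenyl for another aryl group, so neither probes the change in compound 4 directly; they show only that changes at this ester moved this assay by little, and never downward from compound 1. On that basis the step expected for compound 4 is small, a 1.2-fold higher number from compound 1 to compound 4 (0.09 log units; within the scatter), with no clear direction beyond the scatter. Compound 4 is therefore estimated at 0.017 h in this assay, with a range from 0.008 h to 0.036 h.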

Compound 4, half-life: 0.0533 h
For compound 4 the middle estimate is 3.1-fold (0.50 log units) below the measured one; measured number outside the range, above it.
By their numbers in this assay, from the lowest: compounds 1, 2, 3 and 4 (each within the scatter of the next, the first and the last beyond it).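

In this assay, the change confined to the methyl of compound 1 gives a 3.9-fold higher number from compound 1 to compound 4 (0.59 log units; beyond the scatter) and leaves the aryl ester otherwise intact, so this saturated chain carbon bound to an aromatic carbon is a place where nitrooxy in place of hydrogen moves the number beyond the scatter, upward. Compared with the other aryl esters, 2-((nitrooxy)methyl)phenyl gives a 2.9-fold higher number from compound 2 to compound 4 (0.46 log units; beyond the scatter) but only a 1.7-fold higher number from compound 3 to compound 4 (0.22 log units; within the scatter) and so separates compound 4 from compound 2 while leaving it unresolved from compound 3. No measurement shown here bears on why the number rose.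

As far as these compounds go, whether the step in this assay belongs to nitrooxy itself or would follow from other groups at this place stays open, and hydroxymethyl, aminomethyl or a longer chain ending in nitrooxy would test that directly. Also open, from the compounds shown here alone, is whether nitrooxy on a saturated chain carbon carries the same step over to the 4-methoxyphenyl ester of compound 2 or the 4-chloropyridin-3-yl ester of compound 3, or holds only for the 2-methylphenyl ester of compound 1.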